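Ethylamino for (dimethylamino)methyl: compound 3 to compound 4

The compounds below may be only part of what the source reports. "The series", "measured", "known", "first", "only" and "open" are said of these compounds alone.

- compound 1 `O=C(Cn1ccnc1)N1CCC(NS(=O)(=O)c2cc(S(=O)(=O)c3ccccc3)ccc2C(F)(F)F)CC1`: 100000 nM
- compound 2 `CC(=O)N1CCC[C@H]1C(=O)N1CCC(NS(=O)(=O)c2cc(S(=O)(=O)c3ccccc3)ccc2C(F)(F)F)CC1`: 12500 nM
- compound 3 `CN(C)CC(=O)N1CCC[C@H]1C(=O)N1CCC(NS(=O)(=O)c2cc(S(=O)(=O)c3ccccc3)ccc2C(F)(F)F)CC1`: 100000 nM

In a physicochemical assay for solubility (on this read-out higher numbers stand for higher solubility and lower numbers for lower solubility), level with compound 1, compound 3 gives 100000 nM, together the highest of the three numbers. Compound 4 `CCNC(=O)N1CCC[C@H]1C(=O)N1CCC(NS(=O)(=O)c2cc(S(=O)(=O)c3ccccc3)ccc2C(F)(F)F)CC1` carries ethylamino in place of (dimethylamino)methyl on a carbonyl carbon. The closest measured evidence is an 8.0-fold higher number from compound 2 to compound 3 (0.90 log units; beyond the scatter), which came with dimethylamino in place of hydrogen. Compound 4 lacks dimethylamino, as compound 2 does, so a reversal of similar or somewhat smaller size is expected in this assay, towards lower numbers. The expected step is a 5.0-fold lower number from compound 3 to compound 4 (0.70 log units; beyond the scatter). Compound 4 is estimated at 20000 nM, with an expected range of 7000 nM to 60000 nM.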

Compound 4, solubility: 100000 nM
Compound 4: middle estimate off by 5.0-fold (0.70 log units), on the low side; measured number outside the range, above it.
By their numbers in this assay, from the lowest: compound 2; then compounds 1, 3 and 4 (each within the scatter of the next).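

In this assay, among these compounds, the dimethylamino group is not the only change on this carbonyl carbon that goes with a higher number: ethylamino in place of methyl gives an 8.0-fold higher number from compound 2 to compound 4 (0.90 log units; beyond the scatter) at this position. Ethylamino in place of (dimethylamino)methyl gives no change at the digits printed from compound 3 to compound 4 (within the scatter) and 1-(ethylcarbamoyl)pyrrolidin-2-yl in place of (1H-imidazol-1-yl)methyl gives no change at the digits printed from compound 1 to compound 4 (within the scatter), so the urea-type ethylamino group and the amine-bearing groups read alike here. No measured evidence on the cause accompanies these steps.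

Still open, from the compounds shown here alone, is how a carboxylic acid or a longer alkyl chain on this carbonyl carbon would read in this assay.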